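From Fluoro to Methylsulfonyl: an Untested Substituent Swap

The compounds below may be only part of what the source reports. "The series", "measured", "known", "first", "only" and "open" are said of these compounds alone.

Compound 1, `Fc1cccnc1N1CCN(Cc2nc3ccccc3[nH]2)CC1`: 27%
Compound 2, `Fc1ccccc1N1CCN(Cc2nc3ccccc3[nH]2)CC1`: 42%

Of the compounds shown here, two have been measured in an assay on HEK293 cells with D(4) dopamine receptor (Homo sapiens) as the target, read by FLIPR; on this read-out higher numbers stand for larger maximal responses and lower numbers for smaller maximal responses. In this assay compound 1 gives 27%, and compound 2 gives 42%. Compound 1 therefore stands lowest of the two numbers. Among the compounds with values here, the single measured step, a number 15 percentage points higher from compound 1 to compound 2 (beyond the scatter), separates it from compound 2 and comes from a 2-fluorophenyl in place of 3-fluoropyridin-2-yl on an amine nitrogen in a ring.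

Compound 3, `CS(=O)(=O)c1cccnc1N1CCN(Cc2nc3ccccc3[nH]2)CC1`, has not been measured. It differs from compound 1 by methylsulfonyl in place of fluoro on an aromatic carbon, the new group sitting ortho to a large group and two atoms from the ring nitrogen. Within the data shown here, no measured step touches this substituent: the step from compound 1 to compound 2 exchanges the ring that carries the fluoro, not the group itself, so it gives no guide to direction or size. For compound 3 the expectation is therefore a step of a number 3 percentage points higher from compound 1 to compound 3 (within the scatter), which means nothing clearly beyond the scatter. The estimated value for compound 3 is 30%, with a range from 10% to 55%.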

Compound 3, largest response reached (reported as efficacy), in percent of the reference or control that the assay uses: 27%
Compound 3: the middle estimate sits 3 percentage points above what was measured, within the range that was stated.
By their numbers in this assay, from the lowest: compounds 1 and 3 (each within the scatter of the next); then compound 2.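

In this assay, putting methylsulfonyl in place of fluoro on this aromatic carbon, ortho to a large group and two atoms from the ring nitrogen, gives no change at the digits printed from compound 1 to compound 3 (within the scatter) and is the first step shown that changes the substituent itself rather than the ring carrying it. For this one pair of compounds, a group of 4 heavy atoms with 2 hydrogen-bond acceptors thus leaves the maximal response where a single fluorine atom left it, so this position does not demand fluoro, at least when the swap is between these two groups. Nothing available here accounts for the match between the two numbers.

As far as these compounds go, it remains open whether an amine, a carboxylic acid or a longer chain such as ethylsulfonyl on the same carbon would also stay within the scatter of compound 1, or would instead move the response clearly in one direction. Also open, from the compounds shown here alone, is whether methylsulfonyl in place of the fluoro of compound 2 would leave that compound's higher response unchanged.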